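Bridged Diamine Gives Way to Dimethylpiperazine

The source may hold more compounds than are shown below. What is called first, only, known or untested is meant among the compounds shown, and "the series" means these compounds.

Measured in a functional assay on CCRF-CEM cells for antagonist activity at C-X-C chemokine receptor type 4 (Homo sapiens), read by calcium flux, with stated times of 25 min and 90 s; on this read-out higher numbers stand for weaker inhibition and lower numbers for stronger inhibition:
Compound 1, `CN(C[C@H]1Cc2c(cccc2N2C[C@@H]3C[C@H]2CN3)CN1)[C@H]1CCCc2cccnc21`: 146 nM
Compound 2, `Cc1cnc2c(c1)CCC[C@@H]2N(C)C[C@H]1Cc2c(cccc2N2CCNCC2)CN1`: 16.1 nM
Compound 3, `CN1CCN(c2cccc3c2C[C@H](CN(C)[C@H]2CCCc4cccnc42)N(C)C3)CC1`: 171 nM

Among these three numbers compound 1 stands second highest. Compound 3 sits close to it, within the usual scatter of repeated measurements, so the two cannot be told apart. Compound 2 stands well apart at a clearly lower number, beyond the scatter, yet compound 2 differs from compound 1 in more than one place, so no single change can be credited for that gap.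

Compound 4, `CN(C[C@H]1Cc2c(cccc2N2CCNC(C)(C)C2)CN1)[C@H]1CCCc2cccnc21`, has not yet been measured. It differs from compound 1 in one place: a group of 8 heavy atoms (6 carbon, 2 nitrogen; one six-membered non-aromatic ring with 2 hetero atoms) in place of a group of 7 heavy atoms (5 carbon, 2 nitrogen; 2 five-membered non-aromatic rings with 1 hetero atom each), on an aromatic carbon. The ring that enters is of the kind that compound 2 at 16.1 nM and compound 3 at 171 nM also carry, and their numbers lie on both sides of compound 1. On that basis a modest shift toward a lower number is expected in this assay, one that may not exceed the scatter. The expected step is a 2.1-fold lower number from compound 1 to compound 4 (0.32 log units; beyond the scatter). Compound 4 is therefore estimated at 70 nM, with a likely range from 25 nM to 200 nM.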

Compound 4, half-maximal inhibitory concentration: 33.9 nM
Beside the measured number, compound 4's estimate is 2.1-fold (0.31 log units) above it, and the stated range covers the measured number.
By their numbers in this assay, from the lowest: compound 2; then compound 4; then compounds 1 and 3 (each within the scatter of the next).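

In this assay, among the compounds shown here, putting 3,3-dimethylpiperazin-1-yl in place of the bridged group with two five-membered rings on this aromatic carbon gives a 4.3-fold lower number from compound 1 to compound 4 (0.63 log units; beyond the scatter), the first step at this position that can be read on its own. The number moved even though both groups have the same counts of hydrogen-bond donors and acceptors, so those counts alone do not set the result at this position. No measurement here bears on why the number moved.

On these data alone, what the two methyl groups add to the six-membered ring stays open, and the plain piperazin-1-yl group on the core of compound 4 would address that. Also open, as far as these compounds go, is how an open-chain amine, such as a 2-aminoethylamino group, would fare on this carbon.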